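Urea series on a chromane core: nitro for trifluoromethyl

The source may report more compounds than this note shows. Statements on the series, on what has been measured and on what is new or still open speak of the compounds shown alone.

Three diaryl ureas have been run in a functional assay on A2780 cells (Homo sapiens) for inhibition, with a stated time of 72 h, tested at 10 uM; a lower number here means less inhibition of growth, a higher number more inhibition of growth at the concentration tested. Compound 1 `CC1(C)CC(C)(C)c2cc(NC(=O)Nc3ccc([N+](=O)[O-])cc3)ccc2O1` gives 79%, compound 2 `CC1(C)CC(C)(C)c2cc(NC(=O)Nc3ccc(C(F)(F)F)cc3)ccc2O1` gives 88.4%, and compound 3 `CCC1(CC)CC(CC)(CC)c2cc(NC(=O)Nc3ccc(C(F)(F)F)cc3)ccc2O1` gives 86.2%. All three values sit within the scatter of one another, so no order among them is claimed.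

Between compound 2 and compound 1 the change is nitro in place of trifluoromethyl on an aromatic carbon, and the measured step is a number 9.4 percentage points lower from compound 2 to compound 1 (within the scatter). Compound 3 shares the aryl urea part of compound 2 but carries a different core; the difference between the two cores is not broken down here, and the two values are within the scatter.

Compound 4 `CCC1(CC)CC(CC)(CC)c2cc(NC(=O)Nc3ccc([N+](=O)[O-])cc3)ccc2O1`, not yet measured, is made from compound 3 by nitro in place of trifluoromethyl on an aromatic carbon; this is the same change as that from compound 2 to compound 1, at the same place. The expected step is a number 9.2 percentage points lower from compound 3 to compound 4 (within the scatter), resting on the single measured case of the change, a number 9.4 percentage points lower from compound 2 to compound 1 (within the scatter), which lies within the scatter. Compound 4 is therefore expected to land near compound 3 in this assay, estimated at 77%, with a range from 65% to 88%.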

Compound 4, percent growth inhibition at one concentration: 91.4%
Estimate against measurement, compound 4: 14.4 percentage points below, and the stated range ends below it.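

In this assay the change on the core of compound 3 gives a number 5.2 percentage points higher from compound 3 to compound 4 (within the scatter), so the step does not keep its direction or size when moved to this core. Set beside the step on the core of compound 2, the change does not carry over as a fixed amount between these two cores: the same change on two cores in this assay, a number 9.4 percentage points lower (within the scatter) from compound 2 to compound 1 and a number 5.2 percentage points higher (within the scatter) from compound 3 to compound 4, 14.6 percentage points apart, beyond the scatter of two such steps. Among the compounds shown here, each step alone lies within the scatter and each core offers only one pair, so the data do not show which feature of the cores goes with this gap, or how the change would behave on any third core.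

The compounds shown hold only trifluoromethyl and nitro on that aromatic carbon, which leaves open how a nitrile, an amine or a carboxylic acid would read on either core. Also open, going by these compounds, is whether a longer chain on the core would follow the step seen on the core of compound 2, the step seen on the core of compound 3, or neither.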